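This account rests on a few compounds, and the source may have more. Where it says the series, first, only, none or still open, it means among the compounds named here.

For the measured compounds named here, in a functional assay on KB cells (Homo sapiens) for antiproliferative activity, read by sulforhodamine B assay, with a stated time of 72 h (a lower number here means a stronger inhibitor, a higher number a weaker inhibitor), only two compounds have been tested. Compound 1 `COc1c(OC(C)C)cc2oc(-n3cncn3)c(-c3csc4ccccc34)c(=O)c2c1OC(C)C` reached the limit of the assay: in this assay compound 1 gives > 10000 nM, which is a limit rather than a number. Going by the values given here, compound 2 `O=C(/C=C/c1csc2ccccc12)c1ccccc1O` gives 6200 nM in this assay, the only measured number so far. The other value sits at the limit (the limit of > 10000 nM in this assay, at which 1 of the 2 values shown sits). Compound 3 `O=C(/C=C/c1csc2ccccc12)c1cc(F)ccc1O` has not yet been measured. It differs from compound 2 in one place: fluoro in place of hydrogen on an aromatic carbon, on an aromatic carbon of a six-membered aromatic ring of carbon only, para to a hydroxy group. Among the compounds with values here, no step between two measured compounds is available to show what such a swap usually does. The expected step is a 1.2-fold lower number from compound 2 to compound 3 (0.09 log units; within the scatter), a shift no larger than the usual scatter and with no clear direction. Compound 3 is therefore expected to give about 5000 nM in this assay, with a range from 2000 nM to 15000 nM.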

Compound 3, half-maximal inhibitory concentration: 7400 nM
Compound 3: the middle estimate sits 1.5-fold (0.17 log units) below what was measured; low and high end bracket the measured number.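

In this assay, putting fluoro in place of hydrogen on this aromatic carbon, para to a hydroxy group, gives a 1.2-fold higher number from compound 2 to compound 3 (0.08 log units; within the scatter). For the compounds shown here, this is the first step between two measured compounds here, and it shows that this position accepts a single fluorine atom with no shift that can be told apart from the scatter of repeated measurements. Going by these compounds alone, nothing measured so far explains why the number holds, since no available evidence bears on this step.

On these data alone, whether a larger group at the same carbon, such as trifluoromethyl or an amine, would also leave the number within the scatter remains open. A single step at one position also cannot show what fluoro would do on the other aromatic carbons of this ring or on the shared core.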